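Replacing Methyl with Dimethylamino: An Expected Gain

The source may hold more compounds than are shown below. What is called first, only, known or untested is meant among the compounds shown, and "the series" means these compounds.

This account follows a series of four compounds that share one core and differ at an aromatic carbon of the six-membered ring. Compound 1 `C#Cc1cn([C@@H]2O[C@H](CO)[C@@H](O)[C@H]2O)c2ncnc(N(C)C)c12` carries dimethylamino there, and in a functional assay on K562 cells (Homo sapiens), read by MTT assay, with a stated time of 72 h (on this read-out lower numbers stand for stronger inhibition and higher numbers for weaker inhibition), compound 1 gives 260 nM. Compound 2 `COc1ncnc2c1c(-c1cccs1)cn2[C@@H]1O[C@H](CO)[C@@H](O)[C@H]1O` carries methoxy, and in this assay compound 2 gives 6200 nM. Compound 3 `Cc1ncnc2c1c(-c1cccs1)cn2[C@@H]1O[C@H](CO)[C@@H](O)[C@H]1O` carries methyl. In this assay compound 3 reaches only a limit, > 20000 nM; the value the limit of > 20000 nM in this assay, at which 1 of the 3 values shown sits, is therefore not a number. Among the compounds with values here, the one measured step, an at least 3.2-fold higher number from compound 2 to compound 3 (0.50 log units; beyond the scatter), shows that methyl in place of methoxy weakens inhibition; because compound 3 sits at a limit, the true size of that step is not known.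

Compound 4 `CN(C)c1ncnc2c1c(-c1cccs1)cn2[C@@H]1O[C@H](CO)[C@@H](O)[C@H]1O` takes the step (dimethylamino in place of methyl on an aromatic carbon). No measured step covers dimethylamino against methyl directly, but compound 1, the one compound shown with dimethylamino, gives the lowest number of the three, while compound 3 gives only a limit. Compound 1 and compound 4 differ elsewhere as well, so that comparison is indicative only. The expected step is an at least 13-fold lower number from compound 3 to compound 4 (1.12 log units; beyond the scatter), toward stronger inhibition. The estimate for compound 4 in this assay is 1500 nM, expected to lie between 300 nM and 8000 nM.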

Compound 4, half-maximal inhibitory concentration: > 20000 nM
Compound 4 gave a limit, no number (the forecaster's own chance of this, stated with the estimate: 10%); at least 13-fold (1.12 log units) between middle value and limit.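

Within the compounds bearing thiophen-2-yl, dimethylamino in place of methyl brings no readable gain in this assay, since the step cannot be read because compound 3 and compound 4 both stop at a limit and neither gives a number: the limit of > 20000 nM in this assay, at which 2 of the 4 values shown sit.

Against methoxy, the change gives an at least 3.2-fold higher number from compound 2 to compound 4 (0.50 log units; beyond the scatter), so of the three groups shown on this aromatic carbon alongside thiophen-2-yl, only methoxy gives a number rather than a limit. With dimethylamino held constant, thiophen-2-yl in place of ethynyl gives an at least 76-fold higher number from compound 1 to compound 4 (1.88 log units; beyond the scatter), so the low number of compound 1 does not come from dimethylamino alone and depends on the ethynyl group being present as well.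

As far as these compounds go, how far compound 3 and compound 4 lie beyond the limit stays open, and so does whether methoxy or methyl alongside ethynyl would keep a number like that of compound 1. From the compounds shown here alone, it also remains open whether a primary amino group or methylamino on this aromatic carbon, alongside thiophen-2-yl, would give a number or stop at the limit as dimethylamino does.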